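Allyl in place of ethyl on the amine of compound 1

The source may report more compounds than this note shows. Statements on the series, on what has been measured and on what is new or still open speak of the compounds shown alone.

Measured so far:
compound 1 `CCN/C(SC)=C(/C#N)C(=O)Nc1ccc(OCC)cc1`: 16400 nM
compound 2 `CCOc1ccc(-n2nnc3n[nH]c(NC)c3c2=O)cc1`: 7010 nM

In a functional assay on Huh-7 cells (Homo sapiens) for cytotoxicity, read by resazurin assay, with a stated time of 48 h (a higher number here means a weaker inhibitor, a lower number a stronger inhibitor), compound 1 gives the higher of the two numbers. Among the measured compounds shown here, compound 2, built on a different core, gives the nearer and only other value, and the gap between the two lies beyond the usual scatter; no single-point step connects compound 1 and compound 2, so the two values are only placed side by side here.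

Compound 3 `C=CCN/C(SC)=C(/C#N)C(=O)Nc1ccc(OCC)cc1` keeps the core of compound 1 and differs from it in one place: vinyl in place of methyl on a saturated chain carbon bound to an amine nitrogen. For the measured compounds named here, no pair of measured compounds shows a change of this kind, so there is no measured step to lean on. The alteration is small and adds no donor or acceptor, and nothing in the two values recorded points in either direction for it. The step of a 1.2-fold lower number from compound 1 to compound 3 (0.07 log units; within the scatter) is therefore expected to stay within the scatter. For compound 3 in this assay the estimate is 14000 nM, with a range from 6000 nM to 35000 nM that spans the uncertainty of an unanchored change.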

Compound 3, half-maximal inhibitory concentration: 8850 nM
Compound 3: middle estimate off by 1.6-fold (0.20 log units), on the high side; the measured number falls inside the stated range.
By their numbers in this assay, from the lowest: compounds 2, 3 and 1 (each within the scatter of the next, the first and the last beyond it).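

In this assay, among the compounds shown here, the change from ethylamino to allylamino on the core of compound 1 gives a 1.9-fold lower number from compound 1 to compound 3 (0.27 log units; within the scatter) and so provides the first single-place reading at this position, which the two earlier compounds, built on different cores, could not give. Vinyl in place of methyl on a saturated chain carbon bound to an amine nitrogen is tolerated here, with no step that can be told apart from repeat measurement, so this one change gives no sign that the position is sensitive in this cytotoxicity read-out. Nothing available beyond the numbers themselves bears on this result or offers an explanation for it.

As far as these compounds go, whether a longer chain, a benzyl group or a cyclopropylmethyl group on the same amine nitrogen would move the number beyond the scatter remains open, as does the outcome with a plain primary amine at this place. For the compounds shown here, compound 2 remains tied to this position by no single-place step, so nothing yet shows how the same allyl group would read on its core.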